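A few compounds are considered here, and "the series" means these few. Any claim that something is new, unique, unknown or untested is made for them only; others in the source may bear on it.

Among the measured compounds shown here, in a functional assay on MOLM-13 cells (Homo sapiens) for antiproliferative activity (a higher number here means a weaker inhibitor, a lower number a stronger inhibitor), compound 2 (`Cc1c(-c2ccc(-c3ccccc3F)cc2)nc2ccc(F)cc2c1C(=O)NS(C)(=O)=O`) gives 300 nM and stands highest of the two numbers so far, while compound 1 (`Cc1c(-c2ccc(-c3ccccc3F)cc2)nc2ccc(F)cc2c1C(N)=O`) gives 128 nM as the lower one. Next is compound 3 (`Cc1c(-c2ccc(-c3ccccc3F)cc2)nc2ccc(F)cc2c1C(=O)N(C)O`), which has hydroxy(methyl)amino in place of methanesulfonamido on a carbonyl carbon. For the measured compounds named here, only one measured step bears on this change, and it is modest: a 2.3-fold higher number from compound 1 to compound 2 (0.37 log units; beyond the scatter) with methylsulfonyl in place of hydrogen on an amide-type nitrogen. Going by the values given here, no measured compound carries hydroxy(methyl)amino, so the guide is indirect. Among the compounds with values here, compound 3 gives up the methanesulfonamido group that accompanies that step, so in this assay a move to a lower number is expected, no larger than that step and perhaps not beyond the scatter. The expected step is a 1.8-fold lower number from compound 2 to compound 3 (0.25 log units; within the scatter) as an estimate only. For compound 3 the estimate is 170 nM and 50 nM to 600 nM is the expected range.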

Compound 3, half-maximal inhibitory concentration: 5100 nM
Beside the measured number, compound 3's estimate is 30-fold (1.48 log units) below it; measured number outside the range, above it.
By their numbers in this assay, from the lowest: compound 1; then compound 2; then compound 3.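

The group on the carbonyl carbon can shift the number in this assay far more than the earlier step showed: hydroxy(methyl)amino in place of methanesulfonamido gives a 17-fold higher number from compound 2 to compound 3 (1.23 log units; beyond the scatter) and, in place of amino, gives a 40-fold higher number from compound 1 to compound 3 (1.60 log units; beyond the scatter) in the same read-out. Compound 3 carries fewer heavy atoms in this group than compound 2 yet gives the higher number, so the heavy-atom count alone does not order these groups. Nothing measured here accounts for this loss.

On these data alone, whether the loss tracks the hydroxy or the methyl on the nitrogen remains open; a methylamino or a hydroxyamino group on the same carbonyl carbon would separate the two. As far as these compounds go, how a carboxylic acid at this place would compare with compound 1 is also open.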